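The source may report more compounds than this note shows. Statements on the series, on what has been measured and on what is new or still open speak of the compounds shown alone.

In a functional assay on HCT-116 cells (Homo sapiens) for cytotoxicity, read by MTT assay, with a stated time of 48 h, in the presence of a further agent that is not named here (a higher number here means that more compound is needed for the effect, a lower number that less compound is needed), compound 1 (`Cc1nn(C)c2nc(NNC(=O)Nc3cc(Cl)nc(Cl)c3)cc(C3CC3)c12`) gives 67700 nM and compound 2 (`CCN(CC)c1cc(NC(=O)NNc2cc(-c3ccc(F)cc3)c3cnn(C)c3n2)cc(Cl)n1`) gives 29400 nM as the lower number. Compound 1 therefore stands highest of the two, with a gap beyond the scatter. Compound 3 (`Cc1nn(C)c2nc(NNC(=O)Nc3cc(Cl)nc(Cl)c3)cc(C3CCCCC3)c12`) keeps the core of compound 1 but has cyclohexyl in place of cyclopropyl on an aromatic carbon opposite the ring nitrogen. Going by the values given here, no measured pair shows this change alone. In this assay a small step toward a lower number, not beyond the scatter, is expected (a 1.6-fold lower number from compound 1 to compound 3 (0.21 log units; within the scatter)) for this exchange. For compound 3 the expected value is 42000 nM with 16000 nM to 100000 nM as its estimated range.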

Compound 3, half-maximal effective concentration: 38000 nM
Compound 3: middle estimate off by 1.1-fold (0.04 log units), on the high side; measured number inside the range.
By their numbers in this assay, from the lowest: compounds 2, 3 and 1 (each within the scatter of the next, the first and the last beyond it).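

Going by these compounds alone, the first pair that isolates this position shows that, opposite the ring nitrogen, cyclohexyl in place of cyclopropyl gives a 1.8-fold lower number from compound 1 to compound 3 (0.25 log units; within the scatter) in this assay. Changing this ring from 3 to 6 carbons therefore leaves the two compounds within the scatter of each other. No evidence on why this is so is available here. The compounds shown leave open how an amine or a carboxylic acid would read at this position, and whether the exchange behaves alike with the other groups of compound 2.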